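Trimming the hydroxycarbamoyl chain of compound 3

This account rests on a few compounds, and the source may have more. Where it says the series, first, only, none or still open, it means among the compounds named here.

In a functional assay on A549 cells (Homo sapiens) for inhibition (a higher number here means a weaker inhibitor, a lower number a stronger inhibitor), compound 3 `CC(C)c1cc(-c2n[nH]c(=O)n2-c2ccc(C(=O)NCCCCCC(=O)NO)cc2)c(O)cc1O` gives 4600 nM, level with compound 1 `CC(C)c1cc(-c2n[nH]c(=O)n2-c2ccc(C(=O)NCCCCCCC(=O)NO)cc2)c(O)cc1O` at 4600 nM, while compound 2 `CC(C)c1cc(-c2n[nH]c(=O)n2-c2cccc(NC(=O)CCCCC(=O)NO)c2)c(O)cc1O` gives a lower number, 1600 nM. Compound 4 `CC(C)c1cc(-c2n[nH]c(=O)n2-c2ccc(C(=O)NCCCC(=O)NO)cc2)c(O)cc1O` has a shorter chain than compound 3: hydroxycarbamoyl stands in place of 2-(hydroxycarbamoyl)ethyl on a saturated chain carbon, three bonds along the chain from an amide-type nitrogen (hydroxycarbamoyl in place of 2-(hydroxycarbamoyl)ethyl on a saturated chain carbon, three bonds along the chain from an amide-type nitrogen). One measured step is of this kind, with hydroxycarbamoyl in place of (hydroxycarbamoyl)methyl, and it shows no change at the digits printed from compound 1 to compound 3 (within the scatter). The new change removes more of the chain, so that single step is thin evidence. Even so, no shift beyond the usual scatter is expected, and the estimated step is a 1.2-fold higher number from compound 3 to compound 4 (0.08 log units; within the scatter). Compound 4 is estimated at 5500 nM, within a range of 2200 nM to 14000 nM.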

Compound 4, half-maximal inhibitory concentration: 4600 nM
Estimate against measurement, compound 4: 1.2-fold (0.08 log units) above, and the stated range covers the measured number.
By their numbers in this assay, from the lowest: compound 2; then compounds 1, 3 and 4 (each within the scatter of the next).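

Cutting the chain further than the earlier single step gives no change at the digits printed from compound 3 to compound 4 (within the scatter) in this assay and, for the larger cut of hydroxycarbamoyl in place of 3-(hydroxycarbamoyl)propyl, no change at the digits printed from compound 1 to compound 4 (within the scatter) as well. Across these three chain lengths, then, the number in this assay does not register the removal, even when the cut is larger than the one seen before. Nothing measured here accounts for this.

Still open, as far as these compounds go, is whether a longer chain, or a carboxylic acid in place of hydroxycarbamoyl at the chain end, would move the number.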